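Adding a nitrile to the benzyl of compound 3

The compounds below may be only part of what the source reports. "The series", "measured", "known", "first", "only" and "open" are said of these compounds alone.

Measured compounds:
compound 1, `COc1ccccc1N1CCN(CCCNC(=O)NN(Cc2ccc(C#N)cc2)c2ccc(F)cc2)CC1`, in an assay on CHO cells for displacement of a labelled ligand from D(4) dopamine receptor (Homo sapiens), read by radioligand binding (on this read-out lower numbers stand for stronger inhibition and higher numbers for weaker inhibition), compound 1 gives 15 nM
compound 2, `COc1ccccc1N1CCN(CCCNC(=O)NN(Cc2ccccc2)c2ccc(Cl)cc2)CC1`, in this assay compound 2 gives 2.9 nM
compound 3, `COc1ccccc1N1CCN(CCCNC(=O)NN(Cc2ccccc2)c2ccc(Cl)cc2Cl)CC1`, in this assay compound 3 gives 15 nM

Compound 3 stands level with compound 1 at the digits shown, the two of them together giving the highest numbers of the three, while compound 2 lies lowest; the one step among these that differs in a single place is a 5.2-fold higher number from compound 2 to compound 3 (0.71 log units; beyond the scatter).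

Compound 4, `COc1ccccc1N1CCN(CCCNC(=O)NN(Cc2ccc(C#N)cc2)c2ccc(Cl)cc2Cl)CC1`, is reached from compound 3 by cyano in place of hydrogen on an aromatic carbon, the benzyl becoming 4-cyanobenzyl with the new group para to a large group. Among the measured compounds shown here, no measured pair differs only in this way. For the measured compounds named here, compound 1 carries the same nitrile on its benzyl but differs from compound 2 in a second place as well, so the pair of compound 1 and compound 2 shows only that the two changes together move the number from that of compound 2 to that of compound 1, and the share of the nitrile alone cannot be read from it.

Going by the values given here, with no direct precedent, compound 4 is expected to stay within the scatter of compound 3, the estimated step being a 1.3-fold higher number from compound 3 to compound 4 (0.12 log units; within the scatter). Compound 4 is therefore estimated at 20 nM, in a range from 7 nM to 60 nM.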

Compound 4, inhibition constant: 12 nM
Compound 4: the middle estimate sits 1.7-fold (0.22 log units) above what was measured, within the range that was stated.
By their numbers in this assay, from the lowest: compound 2; then compounds 4, 1 and 3 (each within the scatter of the next).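

A direct reading of the nitrile at this position in this assay is a 1.3-fold lower number from compound 3 to compound 4 (0.10 log units; within the scatter) and so, with 2,4-dichlorophenyl on the amine nitrogen, benzyl and 4-cyanobenzyl are not told apart. With 4-cyanobenzyl held in place, changing 4-fluorophenyl to 2,4-dichlorophenyl on that nitrogen gives a 1.3-fold lower number from compound 1 to compound 4 (0.10 log units; within the scatter) and leaves these two groups unseparated as well. The share of the nitrile, which the pair of compound 1 and compound 2 could not give on its own, can now be read on one background, and there it does not exceed the scatter.

Going by these compounds, whether the nitrile would stay as silent with the 4-chlorophenyl of compound 2, and whether an amine, a carboxylic acid or a methoxy group in its place on the benzyl would do the same, remains open. Nothing available here accounts for any of these numbers.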